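The source may report more compounds than this note shows. Statements on the series, on what has been measured and on what is new or still open speak of the compounds shown alone.

Among the measured compounds shown here, in an assay on isolated protein for inhibition of ubiquitin carboxyl-terminal hydrolase 7 (Homo sapiens), read by fluorescence, with stated times of 30 min and 1 h (a higher number here means a weaker inhibitor, a lower number a stronger inhibitor), compound 2 `Cc1cc(Cl)cc(-c2ccnc3cc(CN4C(=O)CCC4=O)sc23)c1CN1CCNC[C@@H]1C` gives 6.6 nM, the higher of the two numbers so far; compound 1 `Cc1cc(Cl)cc(-c2ccnc3cc(CN4C(=O)C5C(C4=O)C5(C)C)sc23)c1C[C@@H]1CNCCO1` gives 0.44 nM in this assay, a lower number that lies beyond the usual scatter. Compound 3 `Cc1cc(Cl)cc(-c2ccnc3cc(CN4C(=O)CCC4=O)sc23)c1O[C@@H]1CCNC[C@@H]1C` has not been measured. It differs from compound 2 in one place: (3-methylpiperidin-4-yl)oxy in place of (2-methylpiperazin-1-yl)methyl on an aromatic carbon. For the measured compounds named here, no step between measured compounds bears on this change, so its size in this assay is open; a shift in either direction is plausible, and a slight weakening is judged somewhat more likely than none. For compound 3 the expected value is 9 nM, within 2 nM to 40 nM. The expected step is a 1.4-fold higher number from compound 2 to compound 3 (0.13 log units; within the scatter).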

Compound 3, half-maximal inhibitory concentration: 2.1 nM
Compound 3: middle estimate off by 4.3-fold (0.63 log units), on the high side; the measured number falls inside the stated range.
By their numbers in this assay, from the lowest: compound 1; then compound 3; then compound 2.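

In this assay, the first step read at this position is a 3.1-fold lower number from compound 2 to compound 3 (0.50 log units; beyond the scatter), so this aromatic carbon tolerates the (3-methylpiperidin-4-yl)oxy group in place of (2-methylpiperazin-1-yl)methyl, with a modest gain. The two groups have the same counts of heavy atoms, donors and acceptors, yet differ in ring hetero atoms, linking atom and defined stereocentres. Nothing measured here accounts for the step.

The change alters these features together, so their separate contributions remain unresolved. A piperidin-4-ylamino group, with an amine nitrogen as the link, remains an open comparison at this position.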